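A few compounds are considered here, and "the series" means these few. Any claim that something is new, unique, unknown or untested is made for them only; others in the source may bear on it.

Measured so far:

compound 1 `CC(=O)Nc1ccc(S(=O)(=O)NNc2ccc(Br)c(C)c2)cc1` — 58 nM
compound 2 `O=S(=O)(NNc1ccc(Br)cc1)c1ccccc1` — 172 nM

In an assay for inhibition of Indoleamine 2,3-dioxygenase 1 (Homo sapiens), read by spectrophotometry, with stated times of 1 h and 4 h (a lower number here means a stronger inhibitor, a higher number a weaker inhibitor), compound 2 gives 172 nM, the higher of the two numbers; compound 1 gives the lower number, and the gap between the two lies beyond the scatter. Compound 1 differs from compound 2 in more than one place, so the gap cannot be tied to any single change.

Compound 3 `O=C(O)c1ccc(S(=O)(=O)NNc2ccc(Br)cc2)cc1` differs from compound 2 by carboxy in place of hydrogen on an aromatic carbon. Within the data shown here, no measured pair isolates this change. Compound 1, which also carries a group on the sulfonyl-bearing ring, gives 58 nM, but its second alteration keeps that from serving as a clean guide. A modest step toward a lower number is expected, at or a little beyond the scatter, so that a 1.7-fold lower number from compound 2 to compound 3 (0.24 log units; within the scatter) is the estimated shift. Compound 3 is expected to give about 100 nM in this assay, between 40 nM and 300 nM.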

Compound 3, half-maximal inhibitory concentration: 61 nM
Estimate against measurement, compound 3: 1.6-fold (0.21 log units) above, within the range that was stated.
By their numbers in this assay, from the lowest: compounds 1 and 3 (each within the scatter of the next); then compound 2.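

Carboxy in place of hydrogen on an aromatic carbon, para to a large group, gives in this assay a 2.8-fold lower number from compound 2 to compound 3 (0.45 log units; beyond the scatter) and is the first change in the series that can be read alone. The step lies beyond the scatter, so this position accepts a carboxy group with a lower number, something compound 1 could not show with its second alteration. The compounds shown offer no measurement that accounts for the step.

On these data alone, it stays open whether the step belongs to carboxy itself or would also appear with a methyl ester, a primary amide, an amine or a nitrile at the same place. As far as these compounds go, it also stays open whether carboxy would give a step of similar size on the core of compound 1 in place of its existing group.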